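Flipping one ring stereocentre in a weakly cytotoxic glycoside

A few compounds are considered here, and "the series" means these few. Any claim that something is new, unique, unknown or untested is made for them only; others in the source may bear on it.

Measured compounds:
- compound 1, `CO[C@H]1O[C@H](COc2ccc(OC3CCCCC3)cc2)[C@@H](O)[C@H](O)[C@H]1Oc1ccc(C(C)C)cc1`: 27000 nM
- compound 2, `CO[C@H]1O[C@H](COc2ccccc2C(C)C)[C@@H](O)[C@H](O)[C@H]1Oc1ccc(OC2CCCCC2)cc1`: 33000 nM
- compound 3, `CO[C@H]1O[C@H](COc2ccc3c(c2)CCCC3)[C@@H](O)[C@H](O)[C@H]1Oc1cccc(C(C)C)c1`: 40000 nM

All three were tested in a functional assay on A549 cells (Homo sapiens) for cytotoxicity, read by MTT assay, with a stated time of 48 h; on this read-out lower numbers stand for an effect already at smaller amounts and higher numbers for an effect only at larger amounts of compound. Compound 1 gives 27000 nM, compound 2 gives 33000 nM and compound 3 gives 40000 nM. The three numbers lie within the usual scatter of one another, so none can be set apart: the nearest to compound 2 is compound 3 and the furthest is compound 1, and both gaps are within the scatter. Every compound here acts only at large amounts.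

Compound 4, `CO[C@@H]1O[C@H](COc2ccccc2C(C)C)[C@@H](O)[C@H](O)[C@H]1Oc1ccc(OC2CCCCC2)cc1`, has not yet been measured. It differs from compound 2 as follows: the two compounds have the same atoms and bonds and differ only in configuration as drawn: 1 of 5 stereo elements differ; a stereocentre at a saturated ring carbon is drawn S in compound 2 and R in compound 4. For the measured compounds named here, no pair of measured compounds differs in this way, so there is nothing here that shows what such a change does.

Given that all three measured compounds sit close together, the step of no change at the digits printed from compound 2 to compound 4 (within the scatter) is expected to be none beyond the scatter. In this assay compound 4 is therefore estimated at 33000 nM, with a range from 15000 nM to 70000 nM.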

Compound 4, half-maximal effective concentration: 41000 nM
Compound 4: middle estimate off by 1.2-fold (0.09 log units), on the low side; the range from low to high includes it.
By their numbers in this assay, from the lowest: compounds 1, 2, 3 and 4 (each within the scatter of the next).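

In this assay, drawing this saturated ring carbon R instead of S gives a 1.2-fold higher number from compound 2 to compound 4 (0.09 log units; within the scatter), so the two configurations at this position cannot be told apart in this assay. For the compounds shown here, this is the first pair here that differs in a single place, and it gives a direct reading of one change that the earlier compounds could not provide. The comparison is a clean one, and its reading rests on one point: the fact that compounds 2 and 4 differ only in the configuration as drawn.

This single pair does not show whether the same flip would read the same way in compound 1 or compound 3, whose side groups differ from those of compound 2. It also leaves open whether this position would matter with another group on the shared core, such as an amine or a carboxylic acid.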